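Swapping an Oxazole for Methoxyphenyl: Expected Cell Tolerance

The source may hold more compounds than are shown below. What is called first, only, known or untested is meant among the compounds shown, and "the series" means these compounds.

Of the compounds shown here, three sharing one core have been tested in a toxicity assay on THP-1 cells (Homo sapiens) for inhibition; a lower number here means that less compound is tolerated, a higher number that more compound is tolerated. Compound 1 `COc1ccc(-c2cnc(NC(=O)c3cnco3)n2C)cc1` reaches only a limit there: in this assay compound 1 gives > 100000 nM, which is the edge of what the assay reports rather than a measured number. Compound 2 `Cn1c(-c2cccc(Br)c2)cnc1NC(=O)c1ccc(F)cc1` likewise sits at a limit, giving > 50000 nM in this assay. Compound 3 `Cn1c(-c2ccc(C#N)cc2)cnc1NC(=O)c1ncc[nH]1` also shows only a limit, > 100000 nM in this assay. So every value seen so far is a limit, and all three compounds are tolerated by the cells up to the highest amounts tested; this is summed up by the limit of > 100000 nM in this assay, at which 2 of the 3 values shown sit, and (the limit of > 50000 nM in this assay, at which 1 of the 3 values shown sits). Compound 1 thus stands at the common limit, with no number that would set it apart from the others.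

Compound 4 `COc1ccc(C(=O)Nc2ncc(-c3ccc(OC)cc3)n2C)cc1` has not yet been measured. It differs from compound 1 in one place: 4-methoxyphenyl in place of 1,3-oxazol-5-yl on a carbonyl carbon. With no measured step between any two of these compounds, there is nothing to show how large an effect such a change has in this assay. Given that compound 1 already gives > 100000 nM, the expectation is that compound 4 remains tolerated and most likely again reaches only a limit. The expected step of a number no higher from compound 1 to compound 4 (the limit leaves the size open) is therefore none beyond the scatter. Compound 4 is estimated at 100000 nM, with a range from 30000 nM to 300000 nM.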

Compound 4, half-maximal cytotoxic concentration: > 100000 nM
Compound 4 ended at the assay's limit (the forecaster's own chance of this, stated with the estimate: 75%); the middle value lies on the limit itself.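

In this assay, among the compounds shown here, compound 1 and compound 4 both end at a limit of the assay, so 4-methoxyphenyl in place of 1,3-oxazol-5-yl on a carbonyl carbon gives no step that can be read. The compounds shown leave open what concentration of either compound the cells would fail to tolerate, and whether this change alters it.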